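From hydroxy to acetoxy on compound 1

The source may hold more compounds than are shown below. What is called first, only, known or untested is meant among the compounds shown, and "the series" means these compounds.

In a functional assay on OCI-My4 cells (Homo sapiens) for antiproliferative activity, read by MTT assay, with a stated time of 72 h (a lower number here means a stronger inhibitor, a higher number a weaker inhibitor), compound 1 `N#C/C(=C\c1cccc(Br)n1)C(=O)N[C@@H](CO)c1ccccc1` gives 3900 nM. Going by the values given here, this is the only number available, so compound 1 cannot yet be ranked. In this assay compound 2 `CCCCCCc1ccc(/C=C(\C#N)C(=O)NC(c2ccccc2)C2CC2)cc1` stands as "not determined" (no result reported). Compound 3 `CC(=O)OC[C@H](NC(=O)/C(C#N)=C/c1cccc(Br)n1)c1ccccc1` has acetyl in place of hydrogen on an oxygen on a saturated carbon, hydroxymethyl to acetoxymethyl: acetyl in place of hydrogen on an oxygen on a saturated carbon. Among the compounds with values here, no measured step is available as a guide, so no shift beyond the scatter is expected in this assay, and neither direction is favoured. The estimated change is a 1.3-fold lower number from compound 1 to compound 3 (0.11 log units; within the scatter). For compound 3 the expected value is 3000 nM, with an estimated range of 1000 nM to 9000 nM.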

Compound 3, half-maximal inhibitory concentration: 2900 nM
Compound 3: middle estimate off by 1.0-fold (0.01 log units), on the high side; low and high end bracket the measured number.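

In this assay, going by these compounds alone, the step gives the first reading at this position: acetyl in place of hydrogen on the oxygen comes with a 1.3-fold lower number from compound 1 to compound 3 (0.13 log units; within the scatter) as the only comparison available. In this single pair, the hydroxy hydrogen is therefore not required to keep the value within the scatter, and the added acetyl is accommodated. Nothing at hand bears on the reason for this.

On these data alone, whether a methyl ether, a carboxylic acid or a longer acyl chain on this carbon would stay within the scatter of compound 1 remains open. As far as these compounds go, whether the same change reads alike on another core is also open.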